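Extending the saturated chain: compound 2 to compound 3

The compounds below may be only part of what the source reports. "The series", "measured", "known", "first", "only" and "open" are said of these compounds alone.

Measured in a functional assay on brain (Rattus norvegicus, strain Wistar) for inhibition; on this read-out higher numbers stand for weaker inhibition and lower numbers for stronger inhibition 
compound 1 `CCCCCCCOc1ccc(-c2c(C)[nH]c(=O)n2C)cc1` gives 5700 nM 
compound 2 `CCCCCCCCCCOc1ccc(-c2c(C)[nH]c(=O)n2C)cc1` gives 6900 nM 

In this assay compound 2 stands at 6900 nM and lies within the scatter of compound 1, so the two values cannot be told apart. The next compound is compound 3 `CCCCCCCCCCCOc1ccc(-c2c(C)[nH]c(=O)n2C)cc1`, which differs from compound 2 by methyl in place of hydrogen on a saturated chain carbon, ten or more bonds along the chain from an oxygen on an aromatic ring on the far end of the same saturated chain.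

Going by the values given here, only one measured step bears on this change: a 1.2-fold higher number from compound 1 to compound 2 (0.08 log units; within the scatter), with propyl in place of hydrogen on the chain. That step stayed within the scatter although it put a larger group on the chain than the single methyl now entering. Two compounds make a thin basis, and nothing measured yet shows how a chain of this length behaves. No step beyond the scatter is therefore expected in this assay, and no direction can be assigned. The estimated step is a 1.0-fold higher number from compound 2 to compound 3 (0.01 log units; within the scatter) and would remain within the scatter. For compound 3 the expected value is 7000 nM, with 3500 nM to 14000 nM as its estimated range.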

Compound 3, half-maximal inhibitory concentration: 9700 nM
Estimate against measurement, compound 3: 1.4-fold (0.14 log units) below, and the stated range covers the measured number.
By their numbers in this assay, from the lowest: compounds 1, 2 and 3 (each within the scatter of the next).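

In this assay, going by these compounds alone, the methyl entering on the saturated chain gives a 1.4-fold higher number from compound 2 to compound 3 (0.15 log units; within the scatter) and so stays inside the scatter, which extends the earlier reading to a place on the chain that no previous step had touched. Read over the full span of the series, the whole extension of the chain gives a 1.7-fold higher number from compound 1 to compound 3 (0.23 log units; within the scatter) and also stays inside the scatter, so even the largest addition shown leaves the three compounds unresolved from one another. No supporting measurement bears on this result.

Open, as far as these compounds go, is whether a much shorter chain such as ethyl, or a chain ending in an amine or a carboxylic acid, would move the number beyond the scatter. Also open is what a change to the core of compound 1 would do, since every step shown lies on the saturated chain.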